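The source may hold more compounds than are shown below. What is called first, only, known or untested is meant among the compounds shown, and "the series" means these compounds.

Compound 1 `CCOc1cc(CN2CCC(NC(=O)c3ccc(Cl)nc3)CC2)cc(OCC)c1-c1ccc(F)cc1`: 76 ug/mL
Compound 2 `CCOc1cc(CN2CCC(NC(=O)c3cncc(C)c3)CC2)cc(OCC)c1-c1ccc(OC(F)(F)F)cc1`: < 1 ug/mL

Within the data shown here, in a physicochemical assay for solubility, in phosphate buffer, at pH 6.5 (on this read-out lower numbers stand for lower solubility and higher numbers for higher solubility), compound 1 gives 76 ug/mL, the only true number measured so far. Compound 2 reads < 1 ug/mL, which is a limit and not a number. Among the measured compounds shown here, compound 1 therefore stands as the single numerical anchor, and no measured step changes just one place.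

Compound 3 `CCOc1cc(CN2CCC(NC(=O)c3ccc(N)nc3)CC2)cc(OCC)c1-c1ccc(F)cc1` keeps the core of compound 1 and changes one group, as amino in place of chloro on an aromatic carbon, turning 6-chloropyridin-3-yl into 6-aminopyridin-3-yl. With only compound 1 at 76 ug/mL as a starting point, a modest rise in this assay is expected, one that may not clear the usual scatter. The expected change is a 1.6-fold higher number from compound 1 to compound 3 (0.20 log units; within the scatter). The estimated value for compound 3 is 120 ug/mL, expected to fall between 40 ug/mL and 350 ug/mL.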

Compound 3, solubility: 123 ug/mL
Compound 3: middle estimate off by 1.0-fold (0.01 log units), on the low side, and the stated range covers the measured number.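

In this assay, placing amino for chloro on an aromatic carbon next to the ring nitrogen gives a 1.6-fold higher number from compound 1 to compound 3 (0.21 log units; within the scatter). This is the first step shown that changes only one place, and it shows that, on the core of compound 1, this read-out does not separate 6-chloropyridin-3-yl from 6-aminopyridin-3-yl. Nothing measured here bears on the reason for this result.

The compounds shown leave open how a carboxylic acid or a methoxy group at this same position would read in this assay. They also leave open whether amino in place of chloro gives a similar step when another part of the core of compound 1 is different.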